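The source may hold more compounds than are shown below. What is called first, only, known or untested is meant among the compounds shown, and "the series" means these compounds.

Measured compounds:
- compound 1 `Cc1nc(SCC(=O)Nc2nc(-c3ccc(Cl)cc3)cs2)n(Nc2ccccc2)c1C`: 12200 nM
- compound 2 `Cc1ccc(Nn2c(SCC(=O)Nc3nc(-c4ccccc4)cs3)nc(C)c2C)cc1`: 5610 nM

In a functional assay on EKVX cells (Homo sapiens) for antiproliferative activity, read by sulforhodamine B assay, with a stated time of 48 h (a higher number here means a weaker inhibitor of growth, a lower number a stronger inhibitor of growth), compound 1 gives 12200 nM, the highest of the two numbers; compound 2 gives 5610 nM, a lower number that lies beyond the scatter. Compound 3 `COc1ccc(Nn2c(SCC(=O)Nc3nc(-c4ccc(Cl)cc4)cs3)nc(C)c2C)cc1` differs from compound 1 by methoxy in place of hydrogen on an aromatic carbon. Among the measured compounds shown here, no measured pair shows this change alone, so its effect is unknown. A small step is expected, a 1.4-fold lower number from compound 1 to compound 3 (0.16 log units; within the scatter), pointing to a slightly lower number but possibly not beyond the scatter. Compound 3 is estimated at 8500 nM, within 3000 nM to 24000 nM.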

Compound 3, concentration for total growth inhibition: > 100000 nM
Compound 3 gave a limit, no number; the forecaster's own chance of this, stated with the estimate: 10%; middle value at least 11-fold (1.07 log units) from the limit.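

In this assay compound 3 gives > 100000 nM, which is a limit of the assay and not a number. Methoxy in place of hydrogen, para to a large group, turning anilino into (4-methoxyphenyl)amino, is therefore no small change here: an at least 8.1-fold higher number from compound 1 to compound 3 (0.91 log units; beyond the scatter). This is the first single-place step among the compounds shown, and it runs toward weaker inhibition of growth.

From the compounds shown here alone, the true size of this step stays open. So does whether a different group at this position, such as an amine or a carboxylic acid, would shift the number in the same direction.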